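The compounds below may be only part of what the source reports. "The series", "measured", "known", "first", "only" and "open" are said of these compounds alone.

Of the compounds shown here, two built on one shared core have been measured in a functional assay on HCT-116 cells (Homo sapiens) for inhibition, read by MTT assay, with a stated time of 48 h, tested at 1 mg/mL; on this read-out higher numbers stand for more inhibition at the one concentration tested (going by the name of the read-out) and lower numbers for less inhibition. Compound 1 `N#CC1=C(N)N2C(=O)CSC2=C(C#N)C1c1ccc(Br)cc1` carries a 4-bromophenyl group; in this assay compound 1 gives 43.6%, the higher of the two numbers. Compound 2 `N#CC1=C(N)N2C(=O)CSC2=C(C#N)C1c1ccc(Cl)cc1Cl` carries a dichlorophenyl group instead; in this assay compound 2 gives 29.9%, a reading lower than that of compound 1 by more than the usual scatter of repeated measurements. Compound 3 `N#CC1=C(N)N2C(=O)CSC2=C(C#N)C1c1ccccc1` has not yet been measured. It differs from compound 1 in one place: hydrogen in place of bromo on an aromatic carbon. Within the data shown here, no measured pair shows this exact change on this core, so the size of its effect is not known from the data; both measured compounds carry halogen on the phenyl ring, and nothing measured shows the bare ring. Removing the bromine is expected to lower the reading modestly, by a number 8.6 percentage points lower from compound 1 to compound 3 (within the scatter). In this assay compound 3 is therefore expected to give about 35%, most likely between 20% and 50%.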

Compound 3, a percentage reported as inhibition, at one concentration (the size of the read-out at that concentration, not a potency): 50.8%
Compound 3: the middle estimate sits 15.8 percentage points below what was measured; measured number outside the range, above it.
By their numbers in this assay, from the lowest: compound 2; then compounds 1 and 3 (each within the scatter of the next).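

In this assay, hydrogen in place of bromo gives a number 7.2 percentage points higher from compound 1 to compound 3 (within the scatter), so on this core the reading does not depend on having bromine at this position, para to a large group. The bare phenyl ring and the 4-bromophenyl ring cannot be told apart here, and a halogen on the ring is not needed for a reading of this size. Nothing measured here offers an explanation for this step.

Still open, going by these compounds, is whether a group of another kind at this position, such as an amine, a methoxy group or a carboxylic acid, would shift the reading by more than the usual scatter, and in which direction. Readings at one concentration also say nothing about the potency of these compounds.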